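A new group on the sulfonyl sulfur of compound 2

A few compounds are considered here, and "the series" means these few. Any claim that something is new, unique, unknown or untested is made for them only; others in the source may bear on it.

In a functional assay on VCaP cells (Homo sapiens) for antiproliferative activity, read by propidium iodide staining, with a stated time of 96 h (on this read-out higher numbers stand for weaker inhibition and lower numbers for stronger inhibition), compound 1 `CC(O)(CS(=O)(=O)c1cccc(S(F)(F)(F)(F)F)c1)C(=O)Nc1cccc(S(F)(F)(F)(F)F)c1` gives 19000 nM while compound 2 `CC(O)(CS(=O)(=O)c1ccccc1C(F)(F)F)C(=O)Nc1cccc(S(F)(F)(F)(F)F)c1` stands at 40800 nM as the higher of the two numbers. That makes compound 2 the weaker inhibitor of the pair, and the gap between them lies beyond the usual scatter of repeated measurements.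

Going by the values given here, compound 3 `CC(O)(CS(=O)(=O)c1cccc(OC(F)(F)F)c1)C(=O)Nc1cccc(S(F)(F)(F)(F)F)c1` keeps the shared core and carries 3-(trifluoromethoxy)phenyl in place of 2-(trifluoromethyl)phenyl on a sulfonyl sulfur as its one change. Among the compounds with values here, two values offer little guidance, and no measurement yet shows what this particular swap does. A slight lean toward a lower number rests only on compound 1 at 19000 nM as the stronger of the pair. The expected change is therefore modest: a 1.6-fold lower number from compound 2 to compound 3 (0.21 log units; within the scatter) would point toward stronger inhibition but is expected to stay within the usual scatter. For compound 3 the estimated value is 25000 nM with an expected range from 10000 nM to 60000 nM once it is tested.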

Compound 3, half-maximal inhibitory concentration: 20200 nM
The estimate for compound 3 lay 1.2-fold (0.09 log units) above the measured number; the measured number falls inside the stated range.
By their numbers in this assay, from the lowest: compounds 1 and 3 (each within the scatter of the next); then compound 2.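

In this assay, going by these compounds alone, placing 3-(trifluoromethoxy)phenyl instead of 2-(trifluoromethyl)phenyl on the sulfonyl sulfur gives a 2.0-fold lower number from compound 2 to compound 3 (0.31 log units; beyond the scatter) as the first one-place change in this set, which shows that the read-out responds to the aryl group at this position. The change is small, but it moves compound 3 into the same range as compound 1. The second step, a 1.1-fold higher number from compound 1 to compound 3 (0.03 log units; within the scatter) and a swap of the group on an aromatic carbon, shows that this read-out does not separate those two compounds, so this exchange leaves the number effectively unchanged. No measurement at hand explains why either step comes out as it does.

The step from compound 2 to compound 3 alters both the group's identity and the number in its name, so these compounds cannot show which of the two matters; 3-(trifluoromethyl)phenyl on the sulfonyl sulfur would separate them. Going by these compounds, it also remains open how this position would respond to a phenyl group bearing an amine or a carboxylic acid.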